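Amide-side chain change on the shared core in PC-3 cells

A few compounds are considered here, and "the series" means these few. Any claim that something is new, unique, unknown or untested is made for them only; others in the source may bear on it.

Measured compounds:
compound 1, `COc1cc2ncnc(N3CCc4ccccc43)c2cc1NC(=O)C=C(C)C`, 7840 nM
compound 2, `CC(C)=CC(=O)Nc1cc2c(N3CCc4ccccc43)ncnc2cc1O[C@@H]1CCOC1`, 4620 nM
compound 3, `CC/C=C/C(=O)Nc1cc2c(N3CCCc4ccccc43)ncnc2cc1OC`, 6310 nM

In a functional assay on PC-3 cells (Homo sapiens) for antiproliferative activity, read by MTT assay, with a stated time of 72 h (on this read-out lower numbers stand for stronger inhibition and higher numbers for weaker inhibition), compound 1 gives the highest number of the three measured. Among the compounds with values here, its nearest neighbour is compound 3 at 6310 nM, a gap within the scatter; the largest gap, to compound 2, is the only single-point step recorded: a 1.7-fold lower number from compound 1 to compound 2 (0.23 log units; within the scatter), with oxolan-3-yl replacing methyl on an oxygen on an aromatic ring, and it too stays within the scatter.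

Compound 4, `CCN(CC)C/C=C/C(=O)Nc1cc2c(N3CCc4ccccc43)ncnc2cc1OC`, is not yet measured. It differs from compound 1 at the amide: 3-(diethylamino)prop-1-en-1-yl in place of 2-methylprop-1-en-1-yl on a carbonyl carbon. The prop-1-en-1-yl chain now carries a diethylamino group in place of the two methyls, and the new chain brings one hydrogen-bond acceptor.

Within the data shown here, no measured step touches this position; the one recorded step, a 1.7-fold lower number from compound 1 to compound 2 (0.23 log units; within the scatter), sits on the ether oxygen and was within the scatter, so it gives no guide to the amide side. Among the measured compounds shown here, with nothing to lean on, the number for compound 4 in this assay is estimated close to that of compound 1, as 4000 nM, range 800 nM to 16000 nM, the expected step being a 2.0-fold lower number from compound 1 to compound 4 (0.29 log units; within the scatter), with a wide range because no measured step bears on this change.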

Compound 4, half-maximal inhibitory concentration: 3690 nM
The estimate for compound 4 lay 1.1-fold (0.04 log units) above the measured number; the measured number falls inside the stated range.
By their numbers in this assay, from the lowest: compounds 4, 2, 3 and 1 (each within the scatter of the next, the first and the last beyond it).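

In this assay, within the data shown here, the amide side chain is the first place on the shared core where a single change gives a step beyond the scatter: a 2.1-fold lower number from compound 1 to compound 4 (0.33 log units; beyond the scatter), a modest step, whereas the change on the ether oxygen, a 1.7-fold lower number from compound 1 to compound 2 (0.23 log units; within the scatter), stayed within it. On this carbonyl carbon, then, 3-(diethylamino)prop-1-en-1-yl can replace 2-methylprop-1-en-1-yl, and the number goes down rather than up, so a chain bearing a tertiary amine is accepted here with a small gain in this cell read-out. No measurement shown here accounts for this step.

Among these compounds, the single pair does not separate the contribution of the diethylamino group from that of losing the two methyls, so a plain alkenyl chain without nitrogen, a dimethylamino group or a ring amine such as piperidine or morpholine at the chain end would be needed to tell whether the nitrogen matters. As far as these compounds go, it also remains open whether the same side chain gives a similar step when combined with the oxolan-3-yl ether of compound 2.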